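A few compounds are considered here, and "the series" means these few. Any claim that something is new, unique, unknown or untested is made for them only; others in the source may bear on it.

In a functional assay on G-361 cells (Homo sapiens) for antiproliferative activity, with a stated time of 72 h (on this read-out higher numbers stand for weaker inhibition and lower numbers for stronger inhibition), compound 1 (`COc1cc(CNc2ncnc3c2ncn3[C@@H]2O[C@H](CO)[C@@H](O)[C@H]2O)cc(OC)c1`) has no number to start from: its entry reads "not determined" (no result reported). Its relative compound 2 (`OC[C@H]1O[C@@H](n2cnc3c(NCc4ccc(F)c(Cl)c4)ncnc32)[C@H](O)[C@@H]1O`) gives > 166000 nM, which is a limit of the assay and not a number. The next compound is compound 3 (`COc1cc(CNc2ncnc3c2ncn3[C@@H]2O[C@H](CO)[C@@H](O)[C@H]2O)cc(OC)c1O`). The step hydroxy in place of hydrogen on an aromatic carbon puts hydroxy in place of hydrogen on an aromatic carbon, ortho to two methoxy groups and para to a large group. With no number for compound 1, the size of this step cannot be read, so only a modest move towards stronger inhibition is expected, and the result may again be a limit. For compound 3, the half-maximal inhibitory concentration is estimated at 60000 nM, within an expected range of 8000 nM to 166000 nM.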

Compound 3, half-maximal inhibitory concentration: > 166000 nM
Compound 3: a limit, no number; the forecaster's own chance of this, stated with the estimate: 45%; middle value at least 2.7-fold (0.44 log units) from the limit.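

Among the compounds shown here, compound 1 has no number and compound 3 has only a limit, so no step between them can be read. On these data alone, whether the added hydroxy changes the inhibition in this assay stays open.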